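Replacing the 1H-indol-3-yl group of compound 1

A few compounds are considered here, and "the series" means these few. Any claim that something is new, unique, unknown or untested is made for them only; others in the source may bear on it.

- compound 1 `Cc1ccc(S/C(=C/c2c[nH]c3ccccc23)C(=O)c2ccc(Br)cc2)cc1`: 10000 nM
- compound 2 `COc1ccccc1/C=C(\C(=O)c1ccc(Cl)cc1)S(=O)(=O)Cc1ccc(Cl)c(Cl)c1`: 1000 nM
- compound 3 `O=C(/C(=C\c1c[nH]c2ccccc12)Sc1ccc(Br)cc1)c1ccc(Br)cc1`: 1000 nM

In a functional assay on DU-145 cells (Homo sapiens) for inhibition, read by trypan blue exclusion, with a stated time of 96 h (on this read-out lower numbers stand for stronger inhibition of growth and higher numbers for weaker inhibition of growth), compound 1 gives 10000 nM, the highest number of the three. Compound 4 `Cc1ccc(S/C(=C/c2ccc(C)s2)C(=O)c2ccc(Br)cc2)cc1` carries 5-methylthiophen-2-yl in place of 1H-indol-3-yl on a double-bonded chain carbon bound to a double-bonded chain carbon. Among the measured compounds shown here, the only measured step is a 10-fold lower number from compound 1 to compound 3 (1.00 log units; beyond the scatter), with bromo in place of methyl on an aromatic carbon. It is beyond the scatter, but it leaves the 1H-indol-3-yl group untouched, so it shows only that this series can respond to a single change. No measurement tests the new group, so no clear shift is expected in this assay. The expected step is a 1.4-fold lower number from compound 1 to compound 4 (0.15 log units; within the scatter). For compound 4 the estimate is 7000 nM, with an expected range from 2000 nM to 20000 nM.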

Compound 4, concentration for 50% growth inhibition: > 100000 nM
Compound 4: only a limit was reported (the forecaster's own chance of this, stated with the estimate: 20%); middle value at least 14-fold (1.15 log units) away from the limit.
By their numbers in this assay, from the lowest: compounds 2 and 3 (each within the scatter of the next); then compound 1. At a limit, above all of these: compound 4.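

In this assay, the group at this position clearly matters: the change gives an at least 10-fold higher number from compound 1 to compound 4 (1.00 log units; beyond the scatter) in one step. Among the compounds shown here, the earlier compounds left the 1H-indol-3-yl group untouched, so this is the first sign that 5-methylthiophen-2-yl in its place weakens growth inhibition. Compound 4 has only a limit, not a number: the limit of > 100000 nM in this assay, at which 1 of the 4 values shown sits.

The compounds shown leave open which part of the change counts, the lost six-membered aromatic ring or the lost hydrogen-bond donor. They also leave open how a plain phenyl ring or an amine would fare here.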